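This account rests on a few compounds, and the source may have more. Where it says the series, first, only, none or still open, it means among the compounds named here.

Compound 1, `Cc1cc(NCc2ccccn2)n2ncc(-c3ccc(F)cc3)c2n1`: < 5000 nM
Compound 2, `Cc1cc(Nc2ccccn2)n2nc(C)c(-c3ccccc3)c2n1`: < 5000 nM
Compound 3, `Cc1cc(NCc2ccco2)n2nc(C)c(-c3ccccc3)c2n1`: < 5000 nM

Of the compounds shown here, three sharing one core have been measured in a physicochemical assay for solubility, read by HPLC, using the shake flask method, measured as kinetic solubility, with a stated time of 2 h, at pH 7.4; on this read-out lower numbers stand for lower solubility and higher numbers for higher solubility. Compound 1 gives < 5000 nM, which is a limit of the assay and not a number. Compound 2 likewise gives < 5000 nM, again a limit. Compound 3 gives < 5000 nM, once more a limit rather than a number. For the measured compounds named here, the one single-point change among the measured compounds, a step that the two limits leave unreadable from compound 2 to compound 3, therefore cannot be read in size or direction. What the measured set shows is summed up by the limit of < 5000 nM in this assay, at which 3 of the 3 values shown sit.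

The next compound, compound 4, `Cc1cc(NCc2ccccn2)n2ncc(-c3cc(F)c(F)c(F)c3)c2n1`, differs from compound 1 by 3,4,5-trifluorophenyl in place of 4-fluorophenyl on an aromatic carbon. Going by the values given here, no measured step touches this kind of change, and the only measured step is itself unreadable. The account of compound 4 must rest on the standing of compound 1 alone, which is a limit. Compound 4 is expected to remain at that limit, and the step that the limit leaves unreadable from compound 1 to compound 4 is expected to be none that the assay can resolve. The estimate for compound 4 in this assay is 1500 nM, with a range from 300 nM to 5000 nM, and a limit rather than a number is expected to be reported again.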

Compound 4, solubility: < 5000 nM
Compound 4: only a limit was reported; the forecaster's own chance of this, stated with the estimate: 85%; the middle value lies beyond the limit too.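

In this assay, for the compounds shown here, compound 1 and compound 4 each gave only a limit and not a number, so no step between these two compounds can be read. The compounds shown leave open how far the true solubility of any of them lies from that limit, and whether the change of phenyl group alters it: the limit of < 5000 nM in this assay, at which 4 of the 4 values shown sit.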